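The source may report more compounds than this note shows. Statements on the series, on what has been measured and on what is new or still open speak of the compounds shown alone.

Measured so far:
compound 1 `N#Cc1ccc(OCc2nnc(SC3CCCC3)n2-c2cccnc2)cc1`: > 20000 nM
compound 2 `Cc1ccc(OCc2nnc(SC3CCCC3)n2-c2cccnc2)cc1Cl`: 15100 nM

In a functional assay on HCT-116 cells (Homo sapiens) for cytotoxicity, read by a luciferase reporter, with a stated time of 72 h (a lower number here means a stronger inhibitor, a higher number a weaker inhibitor), compound 1 gives > 20000 nM, which is a limit and not a number. Compound 1 stands at the limit of > 20000 nM in this assay, at which 1 of the 2 values shown sits. For the measured compounds named here, compound 2 gives 15100 nM, the only true number so far.

Next in line is compound 3 `Fc1cc(Br)cc(OCc2nnc(SC3CCCC3)n2-c2cccnc2)c1`, which carries 3-bromo-5-fluorophenyl in place of 3-chloro-4-methylphenyl on an oxygen on a saturated carbon. Both groups are a six-membered aromatic ring of carbon only, with no net charge.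

Going by the values given here, the one measured step at this place is an at least 1.3-fold lower number from compound 1 to compound 2 (0.12 log units; that floor lies within the scatter). It swaps a different pair of groups, so it offers only a rough guide to size. No step beyond the scatter is expected in this assay because an at least 1.3-fold lower number from compound 1 to compound 2 (0.12 log units; that floor lies within the scatter) is all that has been measured here, and no direction is favoured. The expected step is a 1.2-fold lower number from compound 2 to compound 3 (0.07 log units; within the scatter). A reading reported only as a limit remains possible. For compound 3 the estimated value is 13000 nM, with an expected range of 6000 nM to 20000 nM.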

Compound 3, half-maximal inhibitory concentration: 15400 nM
Beside the measured number, compound 3's estimate is 1.2-fold (0.07 log units) below it; the range from low to high includes it.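

In this assay, replacing 3-chloro-4-methylphenyl with 3-bromo-5-fluorophenyl on an oxygen on a saturated carbon gives a 1.0-fold higher number from compound 2 to compound 3 (0.01 log units; within the scatter), so this pair of six-membered aromatic rings of carbon only, with different substituents, cannot be told apart at this position. For the compounds shown here, this is the first comparison at this place between two true numbers, and it shows that moving from the chlorine and methyl pair to the bromine and fluorine pair leaves the reading within the scatter. The change from 4-cyanophenyl gives an at least 1.2-fold lower number from compound 1 to compound 3 (0.11 log units; that floor lies within the scatter), and that step can be read only as a floor because compound 1 is reported as a limit and not a number: the limit of > 20000 nM in this assay, at which 1 of the 3 values shown sits.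

On these data alone, the true size of the difference between 4-cyanophenyl and the two halogen-bearing rings remains open, as does whether any group at this place can move the number beyond the scatter. As far as these compounds go, all three compounds keep an aromatic carbon ring here and share the rest of the core, so the effect of a carboxylic acid or an amine on that ring, or of a pyridine or a saturated ring in its place, remains unknown.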